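A thiophene carbonyl enters where a propanoyl stood

The source may report more compounds than this note shows. Statements on the series, on what has been measured and on what is new or still open speak of the compounds shown alone.

Compound 1 `CCC(=O)Nc1ccc(C(=O)Nc2ccc(C)c(Nc3nccc(-c4cccnc4)n3)c2)cc1` in an ADME assay on BaF3 cells (Mus musculus) for cytotoxicity, read by CellTiter-Glo and CCK-8 assay, with a stated time of 72 h (a higher number here means a weaker inhibitor of growth, a lower number a stronger inhibitor of growth), gives a limit, > 10000 nM.
Compound 2 `CCC(=O)N(CCN(C)C)Cc1ccc(C(=O)Nc2ccc(C)c(Nc3nccc(-c4cccnc4)n3)c2)cc1` in this assay gives a limit, > 10000 nM.

Both measured values are limits, so the step that the two limits leave unreadable from compound 1 to compound 2 cannot be read. Compound 2 therefore stands only at a limit in this assay, the same limit at which both shown values sit (the limit of > 10000 nM in this assay, at which 2 of the 2 values shown sit). Compound 3 `Cc1ccc(NC(=O)c2ccc(CN(CCN(C)C)C(=O)c3cccs3)cc2)cc1Nc1nccc(-c2cccnc2)n1` differs from compound 2 by thiophen-2-yl in place of ethyl on a carbonyl carbon. No readable measured step bears on this change. Compound 3 is expected to stay at the limit, with an estimated step that the limit leaves unreadable from compound 2 to compound 3. The estimated value of compound 3 is 15000 nM, between 5000 nM and 50000 nM.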

Compound 3, concentration for 50% growth inhibition: > 10000 nM
Compound 3: no number, only a limit; the forecaster's own chance of this, stated with the estimate: 85%; the middle value is on the limit's open side.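

Compound 3 gives only a limit, > 10000 nM, in this assay, and compound 2 also stands at a limit, so no step can be read between them. The compounds shown leave open whether thiophen-2-yl in place of ethyl on the carbonyl carbon changes growth inhibition at all in this assay.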